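The compounds below may be only part of what the source reports. "The series", "measured", "known", "first", "only" and "open" are said of these compounds alone.

Three measured compounds share one core and differ only in the group on the sulfur. Compound 1 `CC(C)c1n[nH]c2c(NCc3ccc(-c4ccccn4)cc3)nc(SCC(O)CN3CCNCC3)nc12` gives 332 nM in a functional assay on HT cells (Homo sapiens) for antiproliferative activity, read by fluorescence, with a stated time of 72 h; on this read-out lower numbers stand for stronger inhibition of growth and higher numbers for weaker inhibition of growth. Compound 2 `CC(C)c1n[nH]c2c(NCc3ccc(-c4ccccn4)cc3)nc(SCC(C)(C)O)nc12` gives 507 nM. Compound 3 `CC(C)c1n[nH]c2c(NCc3ccc(-c4ccccn4)cc3)nc(SC(CO)C(C)C)nc12` gives 980 nM, the highest of the three numbers; the gap a 1.9-fold higher number from compound 2 to compound 3 (0.29 log units; within the scatter) stays within the scatter, while a 3.0-fold higher number from compound 1 to compound 3 (0.47 log units; beyond the scatter) lies beyond it, and a 1.5-fold higher number from compound 1 to compound 2 (0.18 log units; within the scatter) is also within the scatter.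

Compound 4 `CC(C)c1n[nH]c2c(NCc3ccc(-c4ccccn4)cc3)nc(S)nc12` is the truncated analogue: hydrogen in place of 1-(hydroxymethyl)-2-methylpropyl on a sulfur. For the measured compounds named here, all three measured steps change the group on the sulfur, yet each keeps a hydroxylated side chain there; none removes it to a bare hydrogen, so no step covers this change directly. The measured steps run from within the scatter to a modest size, and compound 3 already sits at the high end. A further rise in this assay is therefore expected for compound 4, but with wide uncertainty since the change goes past anything measured. The step of a 1.6-fold higher number from compound 3 to compound 4 (0.21 log units; within the scatter) is the estimated result. Compound 4 is expected to give about 1600 nM, in the range 500 nM to 6000 nM.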

Compound 4, concentration for 50% growth inhibition: 2760 nM
Beside the measured number, compound 4's estimate is 1.7-fold (0.24 log units) below it, and the stated range covers the measured number.
By their numbers in this assay, from the lowest: compounds 1, 2 and 3 (each within the scatter of the next, the first and the last beyond it); then compound 4.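

Replacing the side chain on the sulfur with hydrogen moves the number beyond the scatter from each hydroxylated compound: a 2.8-fold higher number from compound 3 to compound 4 (0.45 log units; beyond the scatter), a 5.4-fold higher number from compound 2 to compound 4 (0.74 log units; beyond the scatter) and an 8.3-fold higher number from compound 1 to compound 4 (0.92 log units; beyond the scatter). Compound 4 still gives 2760 nM, so growth inhibition does not depend on having one of these side chains on the sulfur, although all three compounds that carry one give lower numbers. Nothing available on these compounds explains the difference.

The compounds shown leave open whether the gain follows the hydroxyl or the carbon chain, since each side chain carries both; a plain 2-methylpropyl group on the sulfur would separate the two. On these data alone, it also remains open how a carboxylic acid at the end of the chain, or a longer chain ending in piperazine, would compare with compound 1.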